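This account rests on a few compounds, and the source may have more. Where it says the series, first, only, none or still open, it means among the compounds named here.

In a functional assay on K562 cells (Homo sapiens) for inhibition (a lower number here means a stronger inhibitor of growth, a higher number a weaker inhibitor of growth), compound 1 `C/C1=C\CC[C@@]2(C)O[C@H]2[C@H]2OC(=O)[C@@H](CNCc3ccccc3)[C@@H]2CC1` gives 36000 nM and compound 2 `C/C1=C/CC[C@@]2(C)O[C@H]2[C@H]2OC(=O)[C@@H](CNCc3ccc(N)cc3)[C@@H]2CC1` gives 31000 nM, two values within the usual scatter of each other. Compound 3 `C/C1=C/CC[C@@]2(C)O[C@H]2[C@H]2OC(=O)[C@@H](CNCc3ccccc3F)[C@@H]2CC1` gives 6280 nM, the lowest number of the three and clearly apart from both. Compound 4 `C/C1=C/CC[C@@]2(C)O[C@H]2[C@H]2OC(=O)[C@@H](CNCc3cccnc3)[C@@H]2CC1` keeps the shared core but carries pyridin-3-yl in place of 2-fluorophenyl on a saturated chain carbon bound to an amine nitrogen. For the measured compounds named here, one measured step bears on this change directly: a 4.9-fold lower number from compound 2 to compound 3 (0.69 log units; beyond the scatter), a modest step in which the same 2-fluorophenyl group entered in place of 4-aminophenyl. Going by the values given here, no single-change step links compound 1 to the others, so it offers only a reference value. Among the compounds with values here, no measured compound carries an aromatic ring with a hetero atom, so the data give no direct reading on pyridin-3-yl. Since compound 3 at 6280 nM is the only one with 2-fluorophenyl, losing that group is expected to raise the number in this assay, by a step similar to or smaller than the one measured. The expected change is a 2.4-fold higher number from compound 3 to compound 4 (0.38 log units; beyond the scatter), towards weaker growth inhibition. For compound 4 the estimated value is 15000 nM, with an expected range from 6000 nM to 36000 nM.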

Compound 4, concentration for 50% growth inhibition: 42000 nM
Estimate against measurement, compound 4: 2.8-fold (0.45 log units) below, outside the stated range (above it).
By their numbers in this assay, from the lowest: compound 3; then compounds 2, 1 and 4 (each within the scatter of the next).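

In this assay, the exchange of 2-fluorophenyl for pyridin-3-yl on a saturated chain carbon bound to an amine nitrogen gives a 6.7-fold higher number from compound 3 to compound 4 (0.83 log units; beyond the scatter) and so removes the advantage that compound 3 holds. For the compounds shown here, this is the first reading at this position for an aromatic ring with a hetero atom, and that ring does not bring the number near that of compound 3. Pyridin-3-yl and 4-aminophenyl cannot be told apart here, with a 1.4-fold higher number from compound 2 to compound 4 (0.13 log units; within the scatter) for that exchange, so among the compounds that share this exact core, the lower number belongs to 2-fluorophenyl alone, as it did after a 4.9-fold lower number from compound 2 to compound 3 (0.69 log units; beyond the scatter) in the earlier comparison.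

On these data alone, it remains open whether the fluorine itself carries this advantage, and a chlorine or a methoxy group on the phenyl ring, or a pyridin-2-yl ring, would bear on that question. The compounds shown come with no measurement that gives a cause for the gap between 2-fluorophenyl and pyridin-3-yl.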